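This account rests on a few compounds, and the source may have more. Where it says the series, first, only, none or still open, it means among the compounds named here.

Compound 2 `Cc1ccc(CSc2cc(Cl)c(C)cc2S(=O)(=O)/N=C(\N)n2nc(C)cc2-c2ccccc2)cc1` gives 0.176 h in an ADME assay on microsomes from liver (Homo sapiens) for metabolic stability, read by LC-MS, using NADPH, tested at 5 uM; on this read-out lower numbers stand for a shorter-lived compound and higher numbers for a longer-lived compound; compound 1 `Cc1cccc(CSc2cc(Cl)c(C)cc2S(=O)(=O)/N=C(\N)n2nccc2-c2ccccc2)c1` gives 0.232 h, and compound 3 `Cc1cc(-c2ccccc2)n(/C(N)=N/S(=O)(=O)c2cc(C)c(Cl)cc2SCc2cccc(Cl)c2)n1` gives 0.205 h. Compound 2 has the lowest of the three numbers, but both of the others lie within the scatter of it, so no order among them can be claimed. Compound 4 `Cc1cc(-c2ccccc2)n(/C(N)=N/S(=O)(=O)c2cc(C)c(Cl)cc2SCc2ccccc2C)n1` differs from compound 2 by 2-methylphenyl in place of 4-methylphenyl on a saturated chain carbon bound to a sulfur. Among the measured compounds shown here, only one measured step alters the same place, a 1.2-fold higher number from compound 2 to compound 3 (0.07 log units; within the scatter), and it stayed within the scatter. Since nothing measured at this place moved beyond the scatter, compound 4 is expected to show a step of a 1.1-fold higher number from compound 2 to compound 4 (0.06 log units; within the scatter) in this assay, none beyond the scatter. Compound 4 is therefore estimated to give 0.2 h, within a range from 0.12 h to 0.35 h.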

Compound 4, half-life: 0.154 h
The estimate for compound 4 lay 1.3-fold (0.11 log units) above the measured number; the measured number falls inside the stated range.
By their numbers in this assay, from the lowest: compounds 4, 2, 3 and 1 (each within the scatter of the next).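

With 2-methylphenyl in place of 4-methylphenyl there is a 1.1-fold lower number from compound 2 to compound 4 (0.06 log units; within the scatter) and with 2-methylphenyl in place of 3-chlorophenyl there is a 1.3-fold lower number from compound 3 to compound 4 (0.12 log units; within the scatter) in this assay at this place on a saturated chain carbon bound to a sulfur. Changing where the methyl sits on the phenyl ring therefore did not move the half-life beyond the scatter, and compound 2, compound 3 and compound 4 cannot be put in order. No measurement at hand offers an explanation for these numbers.

The compounds shown leave open whether an amine, a carboxylic acid or a longer chain at this place would shift the half-life beyond the scatter.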